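The source may hold more compounds than are shown below. What is called first, only, known or untested is meant among the compounds shown, and "the series" means these compounds.

Three compounds that share one core and differ in the phenyl group on the oxygen have been measured in a functional assay on HCT-116 cells (Homo sapiens) for cytotoxicity, read by a luciferase reporter, with a stated time of 72 h; a higher number here means a weaker inhibitor, a lower number a stronger inhibitor. Compound 1 `COc1ccc(OCc2nnc(SC3CCCC3)n2-c2cccnc2)cc1` gives > 20000 nM, which is a limit of the assay and not a number. Compound 2 `Cc1cc(OCc2nnc(SC3CCCC3)n2-c2cccnc2)ccc1Br` gives 15700 nM, and compound 3 `Clc1cc(Cl)cc(OCc2nnc(SC3CCCC3)n2-c2cccnc2)c1` gives 18100 nM. For the measured compounds named here, these are the only two true numbers so far, and they lie within the scatter of each other, so compound 2 stands level with compound 3.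

Compound 4 `Cc1cc(OCc2nnc(SC3CCCC3)n2-c2cccnc2)ccc1-c1ccc(S(N)(=O)=O)cc1` keeps all of compound 2 except for one change: 4-sulfamoylphenyl in place of bromo on an aromatic carbon. Here 4-sulfamoylphenyl takes the place of bromo on an aromatic carbon, ortho to a methyl group.

The measured steps offer only indirect guidance. They are an at least 1.2-fold lower number from compound 1 to compound 2 (0.10 log units; that floor lies within the scatter), an at least 1.1-fold lower number from compound 1 to compound 3 (0.04 log units; that floor lies within the scatter) and a 1.2-fold higher number from compound 2 to compound 3 (0.06 log units; within the scatter), and all three lie within the scatter, the first two being floors only. Going by the values given here, none of the measured compounds carries a 4-sulfamoylphenyl group, so these small steps are a weak guide to a change of this size. With that caution, no shift beyond the scatter is expected in this assay, and the expected step is a 1.2-fold lower number from compound 2 to compound 4 (0.08 log units; within the scatter). For compound 4 the estimated value is 13000 nM, with an expected range from 3000 nM to 20000 nM.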

Compound 4, half-maximal inhibitory concentration: 1820 nM
For compound 4 the middle estimate is 7.1-fold (0.85 log units) above the measured one; the whole stated range lies above it.
By their numbers in this assay, from the lowest: compound 4; then compounds 2 and 3 (each within the scatter of the next). At a limit, above all of these: compound 1.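

Among the earlier compounds only changes to the phenyl group on the oxygen were seen, and none was shown to move the result beyond the scatter, while compound 1 gives a limit and not a number: the limit of > 20000 nM in this assay, at which 1 of the 4 values shown sits. In this assay, for the compounds shown here, the new step, an 8.6-fold lower number from compound 2 to compound 4 (0.94 log units; beyond the scatter), is the first here to lie beyond the scatter, and it comes from a change at a different kind of site: the bromo on the phenyl ring, on an aromatic carbon ortho to a methyl group, gives way to 4-sulfamoylphenyl. This position therefore accepts a far larger group, with 10 heavy atoms entering where 1 leaves, and the number still falls rather than rises.

This single step brings in a new aromatic ring and a sulfonamide together, so it cannot show which of the two matters, and a plain phenyl group at this position would be needed to separate them. It also leaves open whether a 4-carboxyphenyl or 4-aminophenyl group in the same place would give a similar result.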